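Estimating a Thiophene Amide on a Shared Core

A few compounds are considered here, and "the series" means these few. Any claim that something is new, unique, unknown or untested is made for them only; others in the source may bear on it.

Measured compounds:
Compound 1, `CCCC(=O)Nc1ccc(N2CCN(c3ccc(OC[C@@H]4CO[C@@](Cn5cncn5)(c5ccc(Cl)cc5Cl)O4)cc3)CC2)cc1`, gives 9930 nM in a functional assay on HepG2 cells (Homo sapiens) for inhibition, read by MTT assay, with a stated time of 48 h; a lower number here means a stronger inhibitor, a higher number a weaker inhibitor.
Compound 2, `O=C(CCCCc1ccccc1)Nc1ccc(N2CCN(c3ccc(OC[C@@H]4CO[C@@](Cn5cncn5)(c5ccc(Cl)cc5Cl)O4)cc3)CC2)cc1`, gives 7010 nM in this assay.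
Compound 3, `O=C(Nc1ccc(N2CCN(c3ccc(OC[C@@H]4CO[C@@](Cn5cncn5)(c5ccc(Cl)cc5Cl)O4)cc3)CC2)cc1)C(/C=C/Cl)C/C=C/C(F)(F)F`, gives 9570 nM in this assay.

Among these three numbers compound 3 stands second highest, with compound 1 nearest and compound 2 furthest, both within the scatter. The measured steps are all small: a 1.4-fold lower number from compound 1 to compound 2 (0.15 log units; within the scatter), a 1.0-fold lower number from compound 1 to compound 3 (0.02 log units; within the scatter), and a 1.4-fold higher number from compound 2 to compound 3 (0.14 log units; within the scatter). The two steps that end at compound 3 both change what sits on the carbonyl carbon and both stay within the scatter.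

Compound 4, `O=C(Nc1ccc(N2CCN(c3ccc(OC[C@@H]4CO[C@@](Cn5cncn5)(c5ccc(Cl)cc5Cl)O4)cc3)CC2)cc1)c1cccs1`, differs from compound 3 by thiophen-2-yl in place of 1-(2-chloroethenyl)-5,5,5-trifluoropent-3-en-1-yl on a carbonyl carbon. Among the compounds with values here, no measured step brings an aromatic ring onto the carbonyl carbon, so the closest guides are the two carbonyl-carbon changes leading to compound 3, neither of which moved the number beyond the scatter. Compound 4 is therefore expected to give an estimate of 9000 nM in this assay, with a range from 3500 nM to 25000 nM. The expected step is a 1.1-fold lower number from compound 3 to compound 4 (0.03 log units; within the scatter), which is no change beyond the scatter.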

Compound 4, half-maximal inhibitory concentration: 9770 nM
The estimate for compound 4 lay 1.1-fold (0.04 log units) below the measured number; low and high end bracket the measured number.
By their numbers in this assay, from the lowest: compounds 2, 3, 4 and 1 (each within the scatter of the next).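

Within the data shown here, compound 4 places an aromatic ring, thiophen-2-yl, directly on the carbonyl carbon whose other neighbour is the amide-type nitrogen, something no earlier compound in this set did, and in this assay all three new steps stay within the scatter (a 1.0-fold higher number from compound 3 to compound 4 (0.01 log units; within the scatter)) (a 1.4-fold higher number from compound 2 to compound 4 (0.14 log units; within the scatter)) (a 1.0-fold lower number from compound 1 to compound 4 (0.01 log units; within the scatter)). This extends the earlier picture from open chains to a five-membered aromatic ring: propyl, 4-phenylbutyl, 1-(2-chloroethenyl)-5,5,5-trifluoropent-3-en-1-yl and thiophen-2-yl on this carbon are not separated by this read-out. Nothing available accounts for this lack of separation.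

As far as these compounds go, whether any group on this carbonyl carbon can move the number beyond the scatter remains open. A phenyl ring, an amine or a carboxylic acid at this place could test that.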